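Pyridinylmethyl amide gives way to a methyl carbamate

The source may report more compounds than this note shows. Statements on the series, on what has been measured and on what is new or still open speak of the compounds shown alone.

Measured compounds:
compound 1, `Cc1cc(C(=O)NCc2cccnc2)nn1Cc1cc(Cl)ccc1OCc1ccccc1`, a limit of > 3.7
compound 2, `Cc1cc(C(=O)NCc2ccncc2)nn1Cc1cc(Cl)ccc1OCc1ccccc1`, a limit of > 3.7
compound 3, `Cc1cc(NC(=O)C2CCCC2)nn1Cc1cc(Cl)ccc1OCc1ccccc1`, 3.5

In a physicochemical assay for lipophilicity, at pH 7.4 (a lower number here means a more polar compound, a higher number a more lipophilic compound), compound 1 sits at a limit, not at a number; (the limit of > 3.7 in this assay, at which 2 of the 3 values shown sit). The step that the two limits leave unreadable from compound 1 to compound 2 therefore says nothing usable, while a number at least 0.20 log units lower from compound 1 to compound 3 (that floor lies within the scatter) and a number at least 0.20 log units lower from compound 2 to compound 3 (that floor lies within the scatter) both point downward, with floors inside the scatter. The unmeasured compound 4, `COC(=O)Nc1cc(C)n(Cc2cc(Cl)ccc2OCc2ccccc2)n1`, differs from compound 1 as follows: (methoxycarbonyl)amino in place of ((pyridin-3-yl)methyl)carbamoyl on an aromatic carbon. Among the measured compounds shown here, the only guide is compound 3, whose step from compound 1 a number at least 0.20 log units lower from compound 1 to compound 3 (that floor lies within the scatter) went down. A larger downward move is expected for compound 4, a number at least 0.50 log units lower from compound 1 to compound 4 (beyond the scatter). Compound 4 is estimated at 3.2, within 2.7 to 3.8.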

Compound 4, distribution coefficient: > 3.7
Compound 4 gave a limit, no number; the forecaster's own chance of this, stated with the estimate: 15%; middle value at least 0.50 log units away from the limit.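

In this assay compound 4 gives > 3.7, which is a limit and not a number. Methoxy in place of cyclopentyl on the carbonyl carbon gives a number at least 0.20 log units higher from compound 3 to compound 4 (that floor lies within the scatter), so the small (methoxycarbonyl)amino group does not bring a readable drop at this aromatic carbon. The steps from compound 1 and from compound 2 to compound 4 cannot be read: the limit of > 3.7 in this assay, at which 3 of the 4 values shown sit.

From the compounds shown here alone, the true positions of these three compounds stay open, so their groups cannot be ranked. Also open, going by these compounds, is whether an amine or a carboxylic acid on this aromatic carbon would give a number in this assay.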